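The source may hold more compounds than are shown below. What is called first, only, known or untested is meant among the compounds shown, and "the series" means these compounds.

Compound 1 `O=C(Nc1cc(-c2ccccc2)nn1-c1ccccc1)c1ccccc1` gives 203 nM in a functional assay on cells for positive allosteric modulation of metabotropic glutamate receptor 5 (Rattus norvegicus), read by calcium flux (a lower number here means that less compound is needed, a higher number that more compound is needed for the effect), and among the three compounds measured its number is the second highest. Compound 2 `O=C(Nc1cc(-c2ccccc2)nn1-c1ccccc1)c1cccc(C(F)(F)F)c1`, at 228 nM, stands nearest to it: the step of a 1.1-fold higher number from compound 1 to compound 2 (0.05 log units; within the scatter) lies within the scatter. Compound 3 `O=C(Nc1cc(-c2ccccc2)nn1-c1ccccc1)c1ccc(C(F)(F)F)cc1`, with 38 nM, stands furthest away, through the step of a 5.3-fold lower number from compound 1 to compound 3 (0.73 log units; beyond the scatter). Compound 4 `O=C(Nc1cc(-c2ccccc2)nn1-c1ccccc1Cl)c1ccccc1` differs from compound 1 by chloro in place of hydrogen on an aromatic carbon. Within the data shown here, no measured step bears directly on this change; the steps between compounds 1, 2 and 3 all concern the ring on the carbonyl carbon, and they ranged from no change to a modest drop. Compound 4 is therefore expected to show no step beyond the scatter, a 1.0-fold lower number from compound 1 to compound 4 (0.01 log units; within the scatter), and its estimated value is 200 nM, within a range of 60 nM to 700 nM.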

Compound 4, half-maximal effective concentration: 62 nM
Compound 4: the middle estimate sits 3.2-fold (0.51 log units) above what was measured; the measured number falls inside the stated range.
By their numbers in this assay, from the lowest: compounds 3 and 4 (each within the scatter of the next); then compounds 1 and 2 (each within the scatter of the next).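

The change from phenyl to 2-chlorophenyl gives a 3.3-fold lower number from compound 1 to compound 4 (0.52 log units; beyond the scatter) in this assay, so a single chloro moves the number beyond the scatter. The earlier steps shown here all lay on the ring on the carbonyl carbon, and this shows that a change elsewhere on the core of compound 1 can do so as well. Nothing available explains this step. The compounds shown leave open whether a methyl, a methoxy or an amine in the same place would give a similar number. They also leave open how this chloro would combine with the 4-(trifluoromethyl)phenyl of compound 3.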